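Notes on the step from compound 2 to compound 3

The source may report more compounds than this note shows. Statements on the series, on what has been measured and on what is new or still open speak of the compounds shown alone.

Of the compounds shown here, two have been read so far in an ADME assay on microsomes from liver (Rattus norvegicus) for metabolic stability, read by LC-MS, with a stated time of 4 h, tested at 1 uM; a higher number here means faster removal of the compound, a lower number slower removal. Within the data shown here, compound 2 `Cc1c(Cc2ccc(C(F)(F)F)nc2)c[nH]c1C(=O)NC(C)c1cnn(C)c1` gives 38000 mL.min-1.g-1, the only actual number available. Compound 1 `Cc1cc(Nc2ccc(S(F)(F)(F)(F)F)cc2)n2nc(C(F)(F)F)nc2n1` gives < 25000 mL.min-1.g-1, which is a limit of the assay and not a number. Compound 2 therefore has no numerical neighbour, and its standing can be judged only from these two entries.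

Compound 3 `Cc1cc(C(C)NC(=O)c2[nH]cc(Cc3ccc(C(F)(F)F)nc3)c2C)no1` has 5-methyl-1,2-oxazol-3-yl in place of 1-methyl-1H-pyrazol-4-yl on a saturated chain carbon bound to an amide-type nitrogen and a saturated chain carbon. Each group is one five-membered aromatic ring with 2 hetero atoms and no net charge, and the rest of the structure is unchanged. Among the measured compounds shown here, no measured step covers this kind of change, so the expectation is anchored on compound 2 at 38000 mL.min-1.g-1. The estimated step of a 1.1-fold higher number from compound 2 to compound 3 (0.02 log units; within the scatter) is expected to stay within the usual scatter, with no firm direction in this assay. For compound 3 the estimated value is 40000 mL.min-1.g-1, with an expected range of 18000 mL.min-1.g-1 to 90000 mL.min-1.g-1.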

Compound 3, intrinsic clearance in microsomes: 51000 mL.min-1.g-1
Compound 3: middle estimate off by 1.3-fold (0.11 log units), on the low side; measured number inside the range.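

Among these compounds, the step is the first measured one: in this assay, 5-methyl-1,2-oxazol-3-yl in place of 1-methyl-1H-pyrazol-4-yl on a saturated chain carbon bound to an amide-type nitrogen and a saturated chain carbon gives a 1.3-fold higher number from compound 2 to compound 3 (0.13 log units; within the scatter). Among the compounds shown here, at this place, then, one five-membered aromatic ring with 2 hetero atoms can stand in for another with no difference that this assay separates from the scatter, something the earlier compounds, with no step between them, could not show. Nothing measured here bears on the cause of this step.

Both rings shown at this place are of one kind, so it remains open whether a different group there, such as a phenyl ring, an amine or a carboxylic acid, would give a step beyond the scatter in this assay. For the compounds shown here, compound 1 shares no single-place step with the other compounds and is read only as a limit of the assay, not a number: the limit of < 25000 mL.min-1.g-1 in this assay, at which 1 of the 3 values shown sits.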